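Fluoro for Methyl on the Aryl Tail

The source may report more compounds than this note shows. Statements on the series, on what has been measured and on what is new or still open speak of the compounds shown alone.

Measured compounds in an assay on THP-1 cells for displacement of a labelled ligand from C-C chemokine receptor type 1 (Homo sapiens); a lower number here means a stronger inhibitor, a higher number a weaker inhibitor:
Compound 1, `Cc1ccc(CCC(=O)N[C@@H](C(=O)N2CCC(c3ccc(Cl)cc3)CC2)C(C)C)cc1`, gives 105 nM.
Compound 2, `CC(C)C(=O)NC(C(=O)N1CCC(c2ccc(Cl)cc2)CC1)C(C)C`, gives 388 nM.
Compound 3, `CC[C@@H](C)[C@@H](NC(=O)CCc1ccccc1)C(=O)N1CCC(c2ccc(Cl)cc2)CC1`, gives 66 nM.

Three compounds share a core built on a chlorophenyl-piperidine amide, and they differ in the acyl tail and the amino acid side chain. Among them compound 1 stands second highest of the three numbers. Its nearest neighbour is compound 3, whose number is lower but within the scatter, so the two cannot be ordered. Compound 2, the only one without an aromatic tail, stands furthest from compound 1, with a higher number that lies beyond the scatter.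

The next compound, compound 4, `CC(C)[C@@H](NC(=O)CCc1ccc(F)cc1)C(=O)N1CCC(c2ccc(Cl)cc2)CC1`, has not yet been measured in this assay. It keeps the core and the propanoyl tail of compound 1 and changes only one atom: fluoro in place of methyl on an aromatic carbon. Such a swap of fluoro in place of methyl on an aromatic carbon, para to a large group, is a small change at the far end of the molecule. Among the compounds with values here, no measured pair shows this exact step, so nothing in the data points to a direction. The step from compound 1 to compound 4 is expected to be a 1.0-fold higher number from compound 1 to compound 4 (0.02 log units; within the scatter), within the scatter. Compound 4 is therefore estimated at 110 nM, with a range from 50 nM to 250 nM.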

Compound 4, half-maximal inhibitory concentration: 70 nM
Beside the measured number, compound 4's estimate is 1.6-fold (0.20 log units) above it; measured number inside the range.
By their numbers in this assay, from the lowest: compounds 3, 4 and 1 (each within the scatter of the next); then compound 2.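

In this assay the change of fluoro in place of methyl on an aromatic carbon, para to a large group, gives a 1.5-fold lower number from compound 1 to compound 4 (0.18 log units; within the scatter) and so leaves the two compounds unordered. This is the first pair among the compounds shown that differs in one place, and it shows that the 4-methylphenyl and 4-fluorophenyl tails cannot be told apart in this measurement, so this single replacement at the far end of the molecule leaves no readable mark on the number. Nothing measured alongside this pair offers an explanation for the step, and the size of the step is all that can be reported.

The compounds shown leave open what a methoxy, a carboxylic acid or an amine at the same place on the aromatic ring would do, since fluoro and methyl are the only two groups compared there. They also leave open whether the same replacement would read the same way with a different amino acid side chain, as compound 3 differs from compound 1 and from compound 4 in more than one place and so gives no such comparison.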